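The compounds below may be only part of what the source reports. "The series", "measured", "known", "first", "only" and "open" are said of these compounds alone.

Compounds measured in an assay for inhibition of Nitric oxide synthase, inducible (Homo sapiens), read by scintillation counting, with a stated time of 30 min; on this read-out lower numbers stand for stronger inhibition and higher numbers for weaker inhibition: compound 1 `CNC(=S)NCCC(O)c1ccccc1N` gives 350000 nM; compound 2 `CNC(=S)NCCC(O)c1cc(OC)ccc1N` gives 130000 nM.

Among the measured compounds shown here, compound 2 stands at the lowest of the two numbers, its only neighbour being compound 1. For the measured compounds named here, the one measured step that bears on compound 3 `CNC(=S)NCCC(O)c1cc(Cl)ccc1N` is the methoxy in place of hydrogen, a 2.7-fold lower number from compound 1 to compound 2 (0.43 log units; beyond the scatter). Compound 3 differs from compound 2 by chloro in place of methoxy on an aromatic carbon. Going by the values given here, no measured compound carries a chloro group, so the direction is uncertain. For compound 3 a step within the scatter, a 1.2-fold higher number from compound 2 to compound 3 (0.06 log units; within the scatter), is expected. The estimate for compound 3 in this assay is 150000 nM, with a range from 50000 nM to 450000 nM.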

Compound 3, half-maximal inhibitory concentration: 710000 nM
Beside the measured number, compound 3's estimate is 4.7-fold (0.68 log units) below it; measured number above the stated range.
By their numbers in this assay, from the lowest: compound 2; then compound 1; then compound 3.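

At this aromatic carbon, para to an amino group, the number can move both ways: chloro in place of hydrogen gives a 2.0-fold higher number from compound 1 to compound 3 (0.31 log units; beyond the scatter) while methoxy in place of hydrogen gave a lower number. The exchange of the two groups is the larger of the steps that lead to compound 3, with a 5.5-fold higher number from compound 2 to compound 3 (0.74 log units; beyond the scatter). Nothing measured here accounts for the opposite directions.

Going by these compounds, whether an amine, a carboxylic acid or an ethoxy group at this carbon would fall below or above compound 2 stays open. So does whether the order of methoxy, hydrogen and chloro holds at the other aromatic carbons.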